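The source may hold more compounds than are shown below. What is called first, only, known or untested is meant among the compounds shown, and "the series" means these compounds.

This set concerns three measured compounds and one not yet measured. Compound 1, `CCCOC(=O)c1c(C)coc1-c1ccc2c(CC)cccc2c1OC`, is read in a functional assay on SK-BR-3 cells (Homo sapiens) for cytotoxicity, read by MTT assay, with a stated time of 72 h; a higher number here means that more compound is needed for the effect, a lower number that less compound is needed. There compound 1 gives only a limit of the assay, > 10 ug/mL. Compound 2, `CCc1cccc2c(OC)c(-c3occ(C)c3C(=O)NC)ccc12`, gives in this assay likewise a limit, > 10 ug/mL. Compound 3, `CCc1cccc2c(OC)c(-c3occ(C)c3COC)ccc12`, gives in this assay a limit as well, > 10 ug/mL. All three sit at the limit of > 10 ug/mL in this assay, at which 3 of the 3 values shown sit, so none of the differences among them can be sized: the step that the two limits leave unreadable from compound 1 to compound 2, the step that the two limits leave unreadable from compound 1 to compound 3 and the step that the two limits leave unreadable from compound 2 to compound 3 each fall between two limits and stay unreadable.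

Compound 4, `CCc1cccc2c(OC)c(-c3occ(C)c3CBr)ccc12`, is the next step from compound 3. The change is bromo in place of methoxy on a saturated chain carbon bound to an aromatic carbon. The measured steps that bear on it are the three just named, all unreadable, so they give no size and no direction to expect in this assay beyond the scatter. With no readable step to lean on, the expected step of a number no higher from compound 3 to compound 4 (the limit leaves the size open) is taken as no change beyond the scatter. Compound 4 is therefore estimated at about 10 ug/mL, within a range from 3 ug/mL to 30 ug/mL, with a fair chance that only a limit is reported again.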

Compound 4, concentration for half-maximal effect: > 10 ug/mL
Compound 4: only a limit was reported (the forecaster's own chance of this, stated with the estimate: 55%); the middle value lies on the limit itself.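

In this assay compound 4 gives > 10 ug/mL, which is a limit of the assay and not a number. Among the compounds shown here, no step between compound 1, compound 2, compound 3 and compound 4 can be read, because all four end at one limit: the limit of > 10 ug/mL in this assay, at which 4 of the 4 values shown sit. The compounds shown leave open whether any of these group changes alters the result in this assay at all.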